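From 4-methoxybenzyl to 1,3-thiazol-2-yl on the amide

The source may report more compounds than this note shows. Statements on the series, on what has been measured and on what is new or still open speak of the compounds shown alone.

Three compounds with a shared core, differing only in the group on the amide nitrogen, have been tested in a functional assay on Bel-7402 cells (Homo sapiens) for cytotoxicity, read by MTT assay; a lower number here means a stronger inhibitor, a higher number a weaker inhibitor. In this assay compound 1 `CCn1cc(C(=O)Nc2cccc([N+](=O)[O-])c2)c(=O)c2cc(F)c(N3CCNC(C)C3)c(F)c21` gives 1000 nM. Compound 2 `CCn1cc(C(=O)Nc2ccc(C(C)=O)cc2)c(=O)c2cc(F)c(N3CCNC(C)C3)c(F)c21` returns only a limit of the assay, > 50000 nM. Compound 3 `CCn1cc(C(=O)NCc2ccc(OC)cc2)c(=O)c2cc(F)c(N3CCNC(C)C3)c(F)c21` gives 10300 nM, the higher of the two true numbers, so it is clearly weaker than compound 1.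

Compound 4 `CCn1cc(C(=O)Nc2nccs2)c(=O)c2cc(F)c(N3CCNC(C)C3)c(F)c21` is still unmeasured. It carries 1,3-thiazol-2-yl in place of 4-methoxybenzyl on an amide-type nitrogen.

The three measured changes at this same place all bear on it. Swapping 3-nitrophenyl for 4-methoxybenzyl gave a 10-fold higher number from compound 1 to compound 3 (1.01 log units; beyond the scatter), and swapping 4-acetylphenyl for 4-methoxybenzyl gave an at least 4.8-fold lower number from compound 2 to compound 3 (0.68 log units; beyond the scatter). Among these three compounds, then, this position is sensitive. Compound 1 and compound 2 both carry a ring directly on that nitrogen, yet the data show an at least 50-fold higher number from compound 1 to compound 2 (1.69 log units; beyond the scatter), so those two point in no single direction. A large move either way is possible, but neither way is favoured, so the expected change is only a 1.5-fold lower number from compound 3 to compound 4 (0.17 log units; within the scatter). For compound 4 the estimated value is 7000 nM, with an expected range from 1000 nM to 50000 nM.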

Compound 4, half-maximal inhibitory concentration: > 50000 nM
Compound 4: only a limit was reported; the forecaster's own chance of this, stated with the estimate: 20%; at least 7.1-fold (0.85 log units) between middle value and limit.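

In this assay compound 4 gives > 50000 nM, which is a limit of the assay. Even so, the earlier compounds left the direction of this change open, and it now proves to be a loss: the change to 1,3-thiazol-2-yl gives an at least 4.8-fold higher number from compound 3 to compound 4 (0.68 log units; beyond the scatter), and set against the 3-nitrophenyl amide it gives an at least 50-fold higher number from compound 1 to compound 4 (1.69 log units; beyond the scatter), so among these compounds a ring placed directly on the amide nitrogen goes with a weak result in compound 2 and compound 4, with compound 1 the one that goes against this pattern. The step between compound 2 and compound 4 cannot be read, since both stop at the same limit: the limit of > 50000 nM in this assay, at which 2 of the 4 values shown sit.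

From the compounds shown here alone, what remains open is whether the stronger result of compound 1 depends on the nitro group itself or on where it sits on the phenyl ring, a question that a 4-nitrophenyl or a 3-aminophenyl group on the amide nitrogen would address. It is also unknown how far compound 2 and compound 4 lie past their limit, so these two cannot be ranked against each other.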